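A Thioether Aryl Swap in a Narrow Range

This account rests on a few compounds, and the source may have more. Where it says the series, first, only, none or still open, it means among the compounds named here.

In a functional assay on HeLa cells (Homo sapiens) for inhibition, read by CCK-8 assay, with a stated time of 72 h, tested at 2 uM (on this read-out lower numbers stand for less inhibition of growth and higher numbers for more inhibition of growth at the one concentration tested), compound 1 (`COc1ccc(SCc2ccc(/C=C/C(=O)Nc3ccccc3N)cc2)cc1OC`) gives 10.1%, compound 2 (`Cc1cc(C)cc(SCc2ccc(/C=C/C(=O)Nc3ccccc3N)cc2)c1`) gives 11.7% and compound 3 (`Nc1ccccc1NC(=O)/C=C/c1ccc(CSc2ccc(Cl)cc2)cc1`) gives 1.94%. Compound 1 thus stands within the scatter of both neighbours. Compound 4 (`CCc1ccc(SCc2ccc(/C=C/C(=O)Nc3ccccc3N)cc2)cc1`) has 4-ethylphenyl in place of 3,4-dimethoxyphenyl on a sulfur. Two measured exchanges at that same place bear on it. With 3,5-dimethylphenyl the result is a number 1.6 percentage points higher from compound 1 to compound 2 (within the scatter), and with 4-chlorophenyl it is a number 8.2 percentage points lower from compound 1 to compound 3 (within the scatter). Neither leaves the scatter, so no step beyond it is expected in this assay. The expected result is a number 2.1 percentage points lower from compound 1 to compound 4 (within the scatter). Compound 4 is estimated at 8%, with an expected range of 1% to 17%.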

Compound 4, percent growth inhibition at one concentration: 3.96%
Compound 4: the middle estimate sits 4 percentage points above what was measured, within the range that was stated.
By their numbers in this assay, from the lowest: compounds 3, 4, 1 and 2 (each within the scatter of the next).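

With 4-ethylphenyl on the sulfur, which carries no hydrogen-bond acceptors where 3,4-dimethoxyphenyl carries 2, the step is a number 6.1 percentage points lower from compound 1 to compound 4 (within the scatter) in this assay, and against the 3,5-dimethylphenyl group it is a number 7.7 percentage points lower from compound 2 to compound 4 (within the scatter). Ethyl in place of chloro on an aromatic carbon gives a number 2 percentage points higher from compound 3 to compound 4 (within the scatter), so all four aryl groups at this position remain within the scatter of one another. Nothing measured here offers an explanation for these small differences. Going by these compounds, whether an amine or a carboxylic acid on the phenyl, or a longer chain in place of ethyl, would produce a step beyond the scatter remains open.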